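The source may hold more compounds than are shown below. What is called first, only, known or untested is meant among the compounds shown, and "the series" means these compounds.

Measured in a functional assay on L1210 cells (Mus musculus) for inhibition (a higher number here means a weaker inhibitor, a lower number a stronger inhibitor), so far:
- compound 1 `O=C1/C(=C/c2cccc(Cl)c2)Cc2ccccc21` gives 41200 nM
- compound 2 `O=C1/C(=C/c2ccc(Cl)cc2)Cc2ccccc21` gives 54100 nM
- compound 3 `O=C1/C(=C/c2cccc(F)c2)CCc2ccccc21` gives 61200 nM

Compound 3 carries the highest of the three numbers, but at 61200 nM it lies within the scatter of both compound 1 and compound 2, so the three values cannot be told apart. All three sit in the same high range of the read-out.

The next compound is compound 4 `Cc1cccc(/C=C2\CCc3ccccc3C2=O)c1`, which differs from compound 3 by methyl in place of fluoro on an aromatic carbon. Among the compounds with values here, no pair of measured compounds differs in only one place, so no measured step bears directly on this change. Within the data shown here, the only guide is the narrow spread of the three values.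

In this assay no step beyond the scatter is expected, and the estimated change is a 1.1-fold lower number from compound 3 to compound 4 (0.05 log units; within the scatter). For compound 4 the expected value is 55000 nM, with an estimated range of 28000 nM to 110000 nM.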

Compound 4, half-maximal inhibitory concentration: 73200 nM
Compound 4: the middle estimate sits 1.3-fold (0.12 log units) below what was measured; the measured number falls inside the stated range.
By their numbers in this assay, from the lowest: compounds 1, 2, 3 and 4 (each within the scatter of the next).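

In this assay, within the data shown here, methyl in place of fluoro on an aromatic carbon, meta to a large group, gives a 1.2-fold higher number from compound 3 to compound 4 (0.08 log units; within the scatter), and this is the first step that isolates a single place. At this place, therefore, the two groups, each a single heavy atom with no hydrogen-bond donors or acceptors, cannot be told apart in this read-out. No measurement at hand accounts for this result or links it to any property of either group.

As far as these compounds go, whether a group of a different kind on the same aromatic carbon, such as an amine, a carboxylic acid or a longer chain, would produce a step beyond the scatter remains open. Also open, from the compounds shown here alone, is whether a change elsewhere on the shared core would do so.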